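This account rests on a few compounds, and the source may have more. Where it says the series, first, only, none or still open, it means among the compounds named here.

Measured compounds:

- compound 1 `Cc1cccc(N2CCC(C(=O)Nc3ccc4c(c3)NC(=O)CO4)CC2)c1`: 490 nM
- compound 2 `CCOC(=O)C1(C)Oc2ccc(NC(=O)C3CCN(c4cc(F)c(F)c(F)c4)CC3)cc2NC1=O`: 870 nM
- compound 3 `CC(=O)N1CCc2cc(NC(=O)C3CCN(c4cccc(C(F)(F)F)c4)CC3)ccc21`: > 9000 nM (a limit)

In a functional assay for antagonist activity at transient receptor potential cation channel subfamily V member 1 (Homo sapiens), read by FLIPR and calcium flux (on this read-out higher numbers stand for weaker inhibition and lower numbers for stronger inhibition), compound 1 gives 490 nM, the lowest of the two numbers shown; compound 2 gives 870 nM, and the gap between the two lies within the usual scatter, so no order can be read from them. Compound 3 returns only a limit, > 9000 nM, in this assay (the limit of > 9000 nM in this assay, at which 1 of the 3 values shown sits).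

Compound 4 `O=C1COc2ccc(NC(=O)C3CCN(c4ccccc4Br)CC3)cc2N1` shares the core of compound 1 and differs from it in one place: 2-bromophenyl in place of 3-methylphenyl on an amine nitrogen in a ring. Among the measured compounds shown here, no pair of measured compounds differs in one place, so no measured step is available to set the size of this change. The structural change keeps the group's atom count and leaves donors and acceptors unchanged, so the step from compound 1 to compound 4 is expected to be small, a 1.1-fold higher number from compound 1 to compound 4 (0.05 log units; within the scatter), with no direction beyond the scatter favoured. For compound 4 the estimate in this assay is 550 nM, with a range from 200 nM to 1800 nM.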

Compound 4, half-maximal inhibitory concentration: 160 nM
The estimate for compound 4 lay 3.4-fold (0.54 log units) above the measured number, and the stated range ends above it.
By their numbers in this assay, from the lowest: compound 4; then compounds 1 and 2 (each within the scatter of the next). At a limit, above all of these: compound 3.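

In this assay, 2-bromophenyl in place of 3-methylphenyl on the amine nitrogen in the ring gives a 3.1-fold lower number from compound 1 to compound 4 (0.49 log units; beyond the scatter). Among the compounds shown here, this is the first step that isolates a single place, and it shows that the read-out responds to the aryl group on this nitrogen even when the swap keeps the heavy-atom count and leaves donors and acceptors unchanged. No measured property among the compounds shown bears on this step, so its cause remains unassigned.

The step changes both the substituent and where it sits on the phenyl group, so the contribution of each cannot be separated. Going by these compounds, how a nitrile or an amine on the phenyl group would compare with the bromine of compound 4 remains open.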